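From an octyl chain to a chlorinated aromatic ring

The compounds below may be only part of what the source reports. "The series", "measured", "known", "first", "only" and "open" are said of these compounds alone.

In a functional assay on PC-3 cells (Homo sapiens) for cytotoxicity, read by sulforhodamine B assay, with a stated time of 72 h (a higher number here means a weaker inhibitor of growth, a lower number a stronger inhibitor of growth), compound 1 `CC(=O)N1c2ccccc2CCC1C(=O)Nc1ccccc1O` gives 70700 nM and compound 2 `CCCCCCCCC(=O)N1c2ccccc2CCC1C(=O)Nc1ccccc1O` gives 45200 nM, so these two values lie within the scatter of each other. Compound 3 `O=C(Nc1ccccc1O)C1CCc2ccccc2N1C(=O)c1cccc(Cl)c1` carries 3-chlorophenyl in place of octyl on a carbonyl carbon. Among the compounds with values here, the only measured step, a 1.6-fold lower number from compound 1 to compound 2 (0.19 log units; within the scatter), lies within the scatter and involves no ring at this place, so it offers weak guidance. No step beyond the scatter is therefore expected in this assay. The estimate means a 1.1-fold lower number from compound 2 to compound 3 (0.05 log units; within the scatter). Compound 3 is expected at 40000 nM, within an estimated range of 12000 nM to 100000 nM.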

Compound 3, concentration for 50% growth inhibition: 23300 nM
Beside the measured number, compound 3's estimate is 1.7-fold (0.23 log units) above it; low and high end bracket the measured number.
By their numbers in this assay, from the lowest: compounds 3, 2 and 1 (each within the scatter of the next, the first and the last beyond it).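

With an aromatic ring on this carbonyl carbon, this assay records a 1.9-fold lower number from compound 2 to compound 3 (0.29 log units; within the scatter) and so cannot tell 3-chlorophenyl from octyl. Set against methyl, the same ring gives a 3.0-fold lower number from compound 1 to compound 3 (0.48 log units; beyond the scatter) as the first step at this position to clear the scatter, though a modest one. A large group here is thus compatible with growth inhibition, whether a chain or a ring.

Going by these compounds, whether the ring or its chlorine matters more stays open, as does how a plain phenyl or a pyridine ring would read at this carbon. No measured evidence accounts for these steps.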